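Pyrimidin-2-yl in place of 1H-benzimidazol-2-yl: working notes

The source may hold more compounds than are shown below. What is called first, only, known or untested is meant among the compounds shown, and "the series" means these compounds.

Measured in an ADME assay on microsomes from liver (Rattus norvegicus) for metabolic stability, read by LC-MS, with a stated time of 10 min, tested at 0.5 uM; on this read-out lower numbers stand for a less stable compound and higher numbers for a more stable compound:
- compound 1 `c1ccc2c(c1)CN[C@H](CN(CCCN1CCNCC1)[C@H]1CCCc3cccnc31)C2`: 88%
- compound 2 `c1cnc2c(c1)CCC[C@@H]2N(CCCN1CCNCC1)Cc1nc2ccccc2[nH]1`: 29%

The lower of the two values belongs to compound 2. Within the data shown here, the one measured step, a number 59 percentage points lower from compound 1 to compound 2 (beyond the scatter), is large and sits at the same place as the next change. Compound 3 `c1cnc(CN(CCCN2CCNCC2)[C@H]2CCCc3cccnc32)nc1` differs from compound 2 as follows: pyrimidin-2-yl in place of 1H-benzimidazol-2-yl on a saturated chain carbon bound to an amine nitrogen. In words, pyrimidin-2-yl stands in place of 1H-benzimidazol-2-yl on a saturated chain carbon bound to an amine nitrogen.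

Among the measured compounds shown here, the measured step shows that a change at this place can move this assay far, but no measurement yet covers pyrimidin-2-yl. With compound 2 at the low end and compound 1 at 88%, a moderate rise is expected, smaller than the measured step. The expected change is a number 21 percentage points higher from compound 2 to compound 3 (beyond the scatter), an uncertain estimate resting on a single step. For compound 3 the estimated value is 50%, with an expected range from 25% to 80%.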

Compound 3, percent of the compound remaining: 68%
Compound 3: the middle estimate sits 18 percentage points below what was measured; measured number inside the range.
By their numbers in this assay, from the lowest: compound 2; then compound 3; then compound 1.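

In this assay the change from 1H-benzimidazol-2-yl to pyrimidin-2-yl on a saturated chain carbon bound to an amine nitrogen gives a number 39 percentage points higher from compound 2 to compound 3 (beyond the scatter) and so shows that this place can recover much of the number lost in compound 2. Pyrimidin-2-yl does not fully match 1,2,3,4-tetrahydroisoquinolin-3-yl, with a number 20 percentage points lower from compound 1 to compound 3 (beyond the scatter) as a modest step, so among these three groups the order runs from 1H-benzimidazol-2-yl through pyrimidin-2-yl to 1,2,3,4-tetrahydroisoquinolin-3-yl. No measurement at hand explains this order.

The change from compound 2 to compound 3 alters the hydrogen-bond donor count and the ring system together, so the compounds shown cannot separate the two. Phenyl and 1H-imidazol-2-yl at this place would bear on that question.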